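A few compounds are considered here, and "the series" means these few. Any claim that something is new, unique, unknown or untested is made for them only; others in the source may bear on it.

Measured in a physicochemical assay for solubility, in phosphate buffer, with a stated time of 2 h, at pH 7.4; on this read-out lower numbers stand for lower solubility and higher numbers for higher solubility:
- compound 1 `CCOc1ccc(-c2csc(Nc3ccc(Cl)cn3)n2)nc1`: a limit, < 10000 nM
- compound 2 `Clc1ccc(Nc2nc(-c3ccccn3)c(Cl)s2)nc1`: a limit, < 10000 nM
- compound 3 `COc1ccc(-c2nc(Nc3ccc(Cl)cn3)sc2Cl)nc1`: a limit, < 10000 nM

Compound 3 has no exact number on this scale. Its entry is only a limit, < 10000 nM. The entries for compound 1 and compound 2 are limits as well, so the three compounds cannot be ranked against one another.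

The next compound is compound 4 `CCOc1ccc(-c2nc(Nc3ccc(Cl)cn3)sc2Cl)nc1`. It differs from compound 3 by a small change at one place, which turns methoxy into ethoxy: methyl in place of hydrogen on a saturated chain carbon bound to an oxygen on an aromatic ring.

The closest measured change is a step that the two limits leave unreadable from compound 2 to compound 3, where methoxy took the place of hydrogen on an aromatic carbon. That step involves a similar group, but it gives no size or direction to carry over. The wider picture is just as uniform: the limit of < 10000 nM in this assay, at which 3 of the 3 values shown sit. No readable step is therefore expected in this assay, and another limit is the most likely report.

A number must still be offered, and it can only be a rough one. Compound 4 is expected to lie near 4000 nM, with an estimated range from 800 nM to 10000 nM. The estimated change is a step that the limit leaves unreadable from compound 3 to compound 4, although the limits show no real direction for it.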

Compound 4, solubility: < 10000 nM
Compound 4: no number, only a limit; the forecaster's own chance of this, stated with the estimate: 85%; the middle value is on the limit's open side.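

Compound 4 also gives only a limit, < 10000 nM, in this assay. No step from compound 1, compound 2 or compound 3 to compound 4 can be read, and the picture stays uniform: the limit of < 10000 nM in this assay, at which 4 of the 4 values shown sit.

The compounds shown leave open how their actual solubilities compare and whether any of these single changes alters solubility.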